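Amino in place of chloro, starting from a limit

This account rests on a few compounds, and the source may have more. Where it says the series, first, only, none or still open, it means among the compounds named here.

In a functional assay on HeLa cells (Homo sapiens) for cytotoxicity, read by neutral red uptake, with a stated time of 3 days (on this read-out lower numbers stand for stronger inhibition and higher numbers for weaker inhibition), compound 1 `Nc1ccc(-c2cc(=O)c3c(N)c(F)c(CO)c(F)c3o2)cc1F` gives 24000 nM. Compound 2 `Nc1ccc(-c2cc(=O)c3c(N)c(F)c(Cl)c(F)c3o2)cc1F` gives > 100000 nM, which is a limit of the assay and not a number. Compound 3 `Nc1ccc(-c2cc(=O)c3c(N)c(F)c(N)c(F)c3o2)cc1F` carries amino in place of chloro on an aromatic carbon. Among the compounds with values here, the only measured step on that carbon is an at least 4.1-fold higher number from compound 1 to compound 2 (0.61 log units; beyond the scatter), with chloro in place of hydroxymethyl, so replacing chloro may well bring a lower number in this assay. A modest estimated step of an at least 2.2-fold lower number from compound 2 to compound 3 (0.34 log units; beyond the scatter) is therefore expected, though one measured step is thin support. Compound 3 is estimated at 45000 nM, with an expected range of 15000 nM to 130000 nM.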

Compound 3, half-maximal inhibitory concentration: 19000 nM
For compound 3 the middle estimate is 2.4-fold (0.37 log units) above the measured one; the range from low to high includes it.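

In this assay, amino in place of chloro brings an at least 5.2-fold lower number from compound 2 to compound 3 (0.72 log units; beyond the scatter). Compound 2 stands at a limit of the assay, so this step has only a bound and no exact size: the limit of > 100000 nM in this assay, at which 1 of the 3 values shown sits. Amino in place of hydroxymethyl brings a 1.3-fold lower number from compound 1 to compound 3 (0.10 log units; within the scatter), so these two groups cannot be told apart here, and of the three groups on this carbon only chloro stands apart. The compounds shown leave open whether a methylamino group or a carboxylic acid on this carbon would match amino, and whether bromo would behave like chloro.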